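Adding a Cyclohexyl Ring to the Shorter Chain

The compounds below may be only part of what the source reports. "The series", "measured", "known", "first", "only" and "open" are said of these compounds alone.

Compound 2 `CCCCCCCCc1ccccc1C(SCCC(=O)O)SCCC(=O)O` is the weakest binder among the three measured compounds: on an assay on membranes from lung (Cavia porcellus) for binding affinity to cysteinyl leukotriene receptor (Homo sapiens) (on this read-out lower numbers stand for stronger inhibition and higher numbers for weaker inhibition), compound 2 gives 5670 nM. Compound 1 `CCCCCCCCCCCCc1ccccc1C(SCCC(=O)O)SCCC(=O)O` gives 445 nM, and compound 3 `O=C(O)CCSC(SCCC(=O)O)c1ccccc1CCCCCCCCCCCC(F)(F)F` gives 147 nM, so compound 2 stands highest of the three numbers. The step of a 13-fold higher number from compound 1 to compound 2 (1.11 log units; beyond the scatter) and the step of a 39-fold lower number from compound 2 to compound 3 (1.59 log units; beyond the scatter) both show that adding chain at this place, eight bonds along the chain from an aromatic carbon, goes with much stronger binding; the step of a 3.0-fold lower number from compound 1 to compound 3 (0.48 log units; beyond the scatter) contributes a modest further gain. Compound 4 `O=C(O)CCSC(SCCC(=O)O)c1ccccc1CCCCCCCCC1CCCCC1` differs from compound 2 by cyclohexyl in place of hydrogen on a saturated chain carbon, eight bonds along the chain from an aromatic carbon. The two steps that bear on this change were both large and in the same direction, and the entering ring brings a comparable amount of carbon to the same place, so a large fall in this assay is expected. The expected step is a 19-fold lower number from compound 2 to compound 4 (1.28 log units; beyond the scatter). Compound 4 is therefore estimated at 300 nM, within a range of 80 nM to 1200 nM.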

Compound 4, inhibition constant: 1960 nM
For compound 4 the middle estimate is 6.5-fold (0.82 log units) below the measured one; measured number above the stated range.
By their numbers in this assay, from the lowest: compound 3; then compound 1; then compound 4; then compound 2.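

Cyclohexyl at this place does improve binding, with a 2.9-fold lower number from compound 2 to compound 4 (0.46 log units; beyond the scatter) in this assay, but this modest gain shows that adding carbon here does not by itself bring a large one. The open chains do better: replacing butyl with cyclohexyl gives a 4.4-fold higher number from compound 1 to compound 4 (0.64 log units; beyond the scatter), and replacing 4,4,4-trifluorobutyl with cyclohexyl gives a 13-fold higher number from compound 3 to compound 4 (1.12 log units; beyond the scatter), so the form of the entering group matters at this place, not just the presence of added carbon. Nothing available here explains why the ring falls short of the open chains.

The compounds shown leave open whether the ring itself or the point where it sits along the chain limits binding. A cyclohexyl ring carried on a longer chain would test the second possibility, and a phenyl ring at the same place would show whether another ring behaves alike.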